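The compounds below may be only part of what the source reports. "The series", "measured", "known", "first", "only" and "open" are said of these compounds alone.

Among the measured compounds shown here, in a functional assay on HCT-116 cells (Homo sapiens) for antiproliferative activity, read by MTT assay, with a stated time of 72 h (a higher number here means a weaker inhibitor, a lower number a stronger inhibitor), compound 1 `O=S1(=O)C=Cc2ccc(Nc3cccc(C(F)(F)F)c3)cc21` gives 1370 nM and is the strongest of the three compounds measured so far. Compound 3 `O=S1(=O)C=Cc2ccc(Nc3ccc(F)c(F)c3)cc21` gives 3020 nM and compound 2 `O=S1(=O)C=Cc2ccc(Nc3ccc(Cl)cc3)cc21` gives 4440 nM and both lie beyond the usual scatter from compound 1 on the weaker side. The next compound to be tested is compound 4 `O=S1(=O)C=Cc2ccc(Nc3cccc(OC(F)(F)F)c3)cc21` which keeps the core of compound 1 and changes one group on an aromatic carbon, with trifluoromethoxy in place of trifluoromethyl on an aromatic carbon as the only difference. For the measured compounds named here, no two measured compounds differ in just one place, so the data hold no direct precedent for this swap. Compound 1 at 1370 nM already has the lowest number of the series, so a modest move upward is expected rather than a further gain. The estimated step of a 1.3-fold higher number from compound 1 to compound 4 (0.12 log units; within the scatter) in this assay is small and may not clear the usual scatter. Compound 4 is therefore expected at 1800 nM with an estimated range of 800 nM to 4200 nM for the coming measurement.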

Compound 4, half-maximal inhibitory concentration: 1980 nM
The estimate for compound 4 lay 1.1-fold (0.04 log units) below the measured number, within the range that was stated.
By their numbers in this assay, from the lowest: compounds 1, 4, 3 and 2 (each within the scatter of the next, the first and the last beyond it).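

In this assay, among the compounds shown here, trifluoromethoxy in place of trifluoromethyl on an aromatic carbon, meta to a large group, gives a 1.4-fold higher number from compound 1 to compound 4 (0.16 log units; within the scatter), the first comparison in which only one place differs. At this position, then, adding an oxygen between the ring and the three fluorines, and with it one hydrogen-bond acceptor by the count, brings no change that can be told apart from repeat-to-repeat variation. No measurement is available that would say why the two groups read alike here.

An amine, a carboxylic acid or a longer chain such as butoxy at this position could still read quite differently. The compounds shown also leave open whether the same swap would read alike at another place on this ring.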